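Swapping an acid for an ester on the pyridine arm

The source may report more compounds than this note shows. Statements on the series, on what has been measured and on what is new or still open speak of the compounds shown alone.

This series of ketone-bearing oxazoles was tested in an assay for inhibition of Fatty-acid amide hydrolase 1 (Rattus norvegicus); a lower number here means a stronger inhibitor, a higher number a weaker inhibitor. Compound 1 `COC(=O)c1cnc(C(=O)CCc2ccc(COc3ccccc3)cc2)o1` gives 1.6 nM, and compound 3 `NC(=O)c1cnc(C(=O)CCc2ccc(Oc3ccccc3)cc2)o1` gives 6.6 nM. Compound 2 `O=C(O)c1cc(-c2cnc(C(=O)CCc3ccc(-c4ccccc4)cc3)o2)ccn1` gives 50 nM, the highest number among the three measured compounds; its gap to compound 3 and its larger gap to compound 1 both lie beyond the usual scatter, so compound 2 is the weakest inhibitor measured so far.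

Compound 4 `COC(=O)c1cccc(-c2cnc(C(=O)CCc3ccc(-c4ccccc4)cc3)o2)n1` has not yet been measured. It differs from compound 2 in one place: 6-(methoxycarbonyl)pyridin-2-yl in place of 2-carboxypyridin-4-yl on an aromatic carbon. The carboxylic acid of compound 2 is thus replaced by a methyl ester, and the pyridine is joined to the shared core through a different ring carbon.

Going by the values given here, no measured pair shows this exact change. Still, an ester-bearing compound, compound 1, gives 1.6 nM, far below compound 2, and an amide-bearing compound, compound 3, gives 6.6 nM. Compound 4 is therefore expected to move to a lower number than compound 2, with a step from a 3.3-fold lower number from compound 2 to compound 4 (0.52 log units; beyond the scatter) that should exceed the scatter but remain modest. Compound 4 is estimated at 15 nM, within a range from 4 nM to 60 nM.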

Compound 4, inhibition constant: 1.2 nM
Compound 4: the middle estimate sits 13-fold (1.10 log units) above what was measured; the measured number lies below the stated range.
By their numbers in this assay, from the lowest: compounds 4 and 1 (each within the scatter of the next); then compound 3; then compound 2.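

In this assay, placing 6-(methoxycarbonyl)pyridin-2-yl instead of 2-carboxypyridin-4-yl on the aromatic carbon next to the ring oxygen produces a large change: a 42-fold lower number from compound 2 to compound 4 (1.62 log units; beyond the scatter). Going by these compounds alone, this is the first pair here that differs in only one place, and it shows that the number in this assay responds strongly to the group carried at this position of the shared core. The step joins two changes in one, a carboxylic acid becoming a methyl ester and the pyridine attaching through a different ring carbon, and no measurement at hand explains its size.

The compounds shown leave open how much of the step belongs to each of those two changes; a pyridine with the carboxylic acid attached as in compound 4, or with the methyl ester attached as in compound 2, would separate them. Going by these compounds, how an ethyl ester or a nitrile would read in place of the methyl ester on this pyridine also remains open.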